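Compound 3 to compound 4: fluoro in place of methyl

The source may hold more compounds than are shown below. What is called first, only, known or untested is meant among the compounds shown, and "the series" means these compounds.

Going by the values given here, in a functional assay on QGY-7703 cells (Homo sapiens) for cytotoxicity, read by MTT assay, with a stated time of 24 h (on this read-out higher numbers stand for weaker inhibition and lower numbers for stronger inhibition), compound 3 `Cc1ccc(S(=O)(=O)N2C/C(=C\c3cccnc3)C(=O)/C(=C/c3ccccc3F)C2)cc1` gives 9700 nM and shares the upper end of the three numbers so far with compound 1 `CN1C/C(=C\c2ccncc2)C(=O)/C(=C/c2ccc(F)cc2Br)C1` at 6900 nM, the two lying within the scatter of each other. Compound 2 `O=C1/C(=C/c2cccnc2)CN(S(=O)(=O)c2ccccc2)C/C1=C\c1ccccc1F` at 4800 nM lies beyond the scatter on the lower side of compound 3.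

The next change leads to compound 4 `O=C1/C(=C/c2cccnc2)CN(S(=O)(=O)c2ccc(F)cc2)C/C1=C\c1ccccc1F` and puts fluoro in place of methyl on an aromatic carbon, para to a large group (fluoro in place of methyl on an aromatic carbon). In other words, (4-methylphenyl)sulfonyl becomes (4-fluorophenyl)sulfonyl.

Among the compounds with values here, only one measured step touches this place: a 2.0-fold higher number from compound 2 to compound 3 (0.31 log units; beyond the scatter) for methyl in place of hydrogen on an aromatic carbon, a modest step. Compound 1 differs from the others in more than this place and gives no direct comparison. No fluoro at this place has been measured, so the reasoning is indirect: compound 4 is expected to fall within the span set by compound 2 and compound 3, nearer the hydrogen case. The step expected is therefore small and toward a lower number (a 1.6-fold lower number from compound 3 to compound 4 (0.21 log units; within the scatter)).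

For compound 4 the estimated value is 6000 nM (expected range 3000 nM to 11000 nM).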

Compound 4, half-maximal inhibitory concentration: 15300 nM
Beside the measured number, compound 4's estimate is 2.6-fold (0.41 log units) below it, and the stated range ends below it.
By their numbers in this assay, from the lowest: compounds 2, 1, 3 and 4 (each within the scatter of the next, the first and the last beyond it).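

In this assay, this place now carries three substituents, and 4-fluorophenyl cannot be told apart from 4-methylphenyl (a 1.6-fold higher number from compound 3 to compound 4 (0.20 log units; within the scatter)), so exchanging one for the other has no readable effect here. The clearer contrast is with the unsubstituted phenylsulfonyl compound: fluoro at this place gives a step beyond the scatter (a 3.2-fold higher number from compound 2 to compound 4 (0.50 log units; beyond the scatter)), in the same direction as the step for methyl (a 2.0-fold higher number from compound 2 to compound 3 (0.31 log units; beyond the scatter)), so among compounds 2, 3 and 4 both substituents go with a higher number than hydrogen, and fluoro does not stay close to the hydrogen case. No measurement is at hand that accounts for these steps.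

On these data alone, it remains open whether this direction holds for other groups at this place, such as methoxy, an amine, a carboxylic acid or a longer chain, or for the same fluoro or methyl placed elsewhere on the ring. As far as these compounds go, it also remains open whether any substituent here can give a number lower than that of compound 2 (4800 nM), and whether the steps carry over to the other arrangement of the shared core seen in compound 1.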